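Hydroxamate-bearing pyrimidines: moving a chlorine around the phenyl ring

The compounds below may be only part of what the source reports. "The series", "measured", "known", "first", "only" and "open" are said of these compounds alone.

Three compounds were measured in a functional assay on MOLT-4 cells (Homo sapiens) for antiproliferative activity, read by MTT assay, with a stated time of 48 h; on this read-out higher numbers stand for weaker inhibition and lower numbers for stronger inhibition:

Compound 1 `O=C(CCCCCn1cc(Nc2ncc(Cl)c(Nc3ccc(Cl)cc3)n2)cn1)NO` gives 80 nM.
Compound 2 `O=C(CCCCCn1cc(Nc2ncc(Cl)c(Nc3ccccc3Cl)n2)cn1)NO` gives 630 nM.
Compound 3 `O=C(CCCCCCn1cc(Nc2ncc(Cl)c(Nc3ccccc3Cl)n2)cn1)NO` gives 510 nM.

All three share a hydroxamic acid at the end of a flexible chain, a pyrazole, and a chloro-substituted pyrimidine carrying a chlorophenylamino group. They differ in two places. One is the chain length: compound 3 differs from compound 2 by (hydroxycarbamoyl)methyl in place of hydroxycarbamoyl on a saturated chain carbon, five bonds along the chain from an aromatic nitrogen, and in this assay this gave a 1.2-fold lower number from compound 2 to compound 3 (0.09 log units; within the scatter), so the longer and the shorter chain behave alike here. The other is where the chlorine sits on the phenyl ring: compound 1 differs from compound 2 by 4-chlorophenyl in place of 2-chlorophenyl on a nitrogen on an aromatic ring, and this gave a 7.9-fold lower number from compound 2 to compound 1 (0.90 log units; beyond the scatter), a clearly larger effect than the chain change.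

Compound 4 `O=C(CCCCCCn1cc(Nc2ncc(Cl)c(Nc3ccc(Cl)cc3)n2)cn1)NO` has not yet been measured. It differs from compound 3 by 4-chlorophenyl in place of 2-chlorophenyl on a nitrogen on an aromatic ring, the same change that was made from compound 2 to compound 1, at the same place. Since the chain difference between compound 3 and compound 2 hardly mattered in this assay, the step from compound 3 to compound 4 is expected to resemble the earlier one, estimated at a 7.3-fold lower number from compound 3 to compound 4 (0.86 log units; beyond the scatter). On that basis compound 4 is expected to give about 70 nM in this assay, most likely between 30 nM and 200 nM.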

Compound 4, half-maximal inhibitory concentration: 120 nM
For compound 4 the middle estimate is 1.7-fold (0.23 log units) below the measured one; measured number inside the range.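

In this assay, within the data shown here, 4-chlorophenyl in place of 2-chlorophenyl again gives a clear step on the longer chain, a 4.3-fold lower number from compound 3 to compound 4 (0.63 log units; beyond the scatter), and its size agrees with the step on the shorter chain: the same change on two cores in this assay, a 7.9-fold lower number (0.90 log units; beyond the scatter) from compound 2 to compound 1 and a 4.3-fold lower number (0.63 log units; beyond the scatter) from compound 3 to compound 4, 1.9-fold (0.27 log units) apart, within the scatter of two such steps The chain change also carries across, since with 4-chlorophenyl in place of 2-chlorophenyl it gives a 1.5-fold higher number from compound 1 to compound 4 (0.18 log units; within the scatter), again a step too small to read as a real difference, and the two chain steps agree: the same change on two cores in this assay, a 1.2-fold lower number (0.09 log units; within the scatter) from compound 2 to compound 3 and a 1.5-fold higher number (0.18 log units; within the scatter) from compound 1 to compound 4, 1.9-fold (0.27 log units) apart, within the scatter of two such steps This shows that, for these four compounds, the chlorine position and the chain length can be read as two separate changes, but it rests on only two pairs of compounds in a single cell assay, so it does not show that the steps are identical, that they would hold on a different core, or why the chlorine position matters.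

The compounds shown leave open how a plain phenyl, or a bromine in place of the chlorine on the phenyl ring, would compare with these chlorophenyl compounds. They also leave open whether the same picture would hold with a much longer chain, or with a carboxylic acid in place of the hydroxamic acid.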